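This account rests on a few compounds, and the source may have more. Where it says the series, first, only, none or still open, it means among the compounds named here.

Compound 1 `CC(C)c1ccc(NC(=O)N(Cc2ccc(C(=O)NCCC(=O)O)cc2)[C@H]2CC[C@H](C(C)(C)C)CC2)cc1` gives 35 nM in an in vitro assay on BHK cells for inhibition of Glucagon receptor (Homo sapiens); a higher number here means a weaker inhibitor, a lower number a stronger inhibitor. Compound 2 `CC(C)(C)[C@H]1CC[C@H](N(Cc2ccc(C(=O)NCCC(=O)O)cc2)C(=O)Nc2cc(C(F)(F)F)cc(C(F)(F)F)c2)CC1` gives 56 nM in this assay. Compound 1 holds the lower of these two numbers, but the gap to compound 2 lies within the scatter of repeated measurements, so the two cannot be told apart on potency. Compound 3 `CC(C)(C)[C@H]1CC[C@H](N(Cc2ccc(C(=O)NCCC(=O)O)cc2)C(=O)Nc2ccc(OCC3CC3)cc2)CC1` is compound 1 with a single change: cyclopropylmethoxy in place of isopropyl on an aromatic carbon. For the measured compounds named here, no pair of measured compounds shows what such a swap does in this assay, so there is no measured step to lean on, only the observation that the two measured compounds, which differ widely in this same part of the molecule, give numbers close to each other. On that basis, the step from compound 1 to compound 3 is expected to be a 1.1-fold higher number from compound 1 to compound 3 (0.06 log units; within the scatter), not beyond the scatter. Compound 3 is estimated at 40 nM, with a range from 14 nM to 120 nM.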

Compound 3, half-maximal inhibitory concentration: 140 nM
Beside the measured number, compound 3's estimate is 3.5-fold (0.54 log units) below it; the whole stated range lies below it.
By their numbers in this assay, from the lowest: compounds 1 and 2 (each within the scatter of the next); then compound 3.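

In this assay, for the compounds shown here, cyclopropylmethoxy in place of isopropyl on an aromatic carbon, para to a large group, gives a 4.0-fold higher number from compound 1 to compound 3 (0.60 log units; beyond the scatter) and so shows that a single change at this position can move the number beyond the scatter, which the earlier compounds could not show. The change brings in an oxygen and a three-membered ring together, so this one step cannot say which of them, or the larger group as a whole, goes with the higher number. Nothing measured here accounts for that shift.

Open, on these data alone, is whether a methoxy group, which carries the oxygen without the ring, or a cyclopropyl group, which carries the ring without the oxygen, would stay closer to compound 1. As far as these compounds go, an amine at this place is equally open.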